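Pyrazolyl in Place of Diethylamino: Estimating Compound 4

The source may report more compounds than this note shows. Statements on the series, on what has been measured and on what is new or still open speak of the compounds shown alone.

Compound 1 `CCN(CC)c1ccc(C(=O)N2CCCCc3ccccc32)c(Cl)c1` gives 19 nM in an assay on HeLa cells for binding affinity to Vasopressin V2 receptor (Homo sapiens); on this read-out higher numbers stand for weaker inhibition and lower numbers for stronger inhibition.
Compound 2 `O=C(c1ccc(N2CCCC2)cc1)N1CCCCc2cc(Cl)ccc21` gives 210 nM in this assay.
Compound 3 `O=C(c1ccc(N2CCCC2)cc1Cl)N1CCCCc2cc(Cl)ccc21` gives 16 nM in this assay.

Among these three numbers compound 1 stands second highest. Its nearest neighbour is compound 3, whose value lies within the usual scatter of that of compound 1, so no order between the two can be claimed. Compound 2 is the furthest away, with a number beyond the scatter above compound 1.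

Among the measured compounds shown here, only one pair of measured compounds differs in a single place: the step of a 13-fold lower number from compound 2 to compound 3 (1.12 log units; beyond the scatter), in which a chloro group enters an aromatic carbon of the core. That position is already occupied by chloro in compound 1 and stays so in compound 4, so this step does not speak to the change now in question.

Compound 4 `O=C(c1ccc(-n2cccn2)cc1Cl)N1CCCCc2ccccc21` differs from compound 1 in one place: 1H-pyrazol-1-yl in place of diethylamino on an aromatic carbon. For the measured compounds named here, no measured pair exchanges this group, so nothing on record shows how this assay responds to it. The expectation therefore rests on compound 1 at 19 nM and carries a wide range. A modest shift toward a higher number, a 2.1-fold higher number from compound 1 to compound 4 (0.32 log units; beyond the scatter), is expected, well within what an untested change could bring. Compound 4 is estimated at 40 nM, with a range from 8 nM to 200 nM.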

Compound 4, half-maximal inhibitory concentration: 8.8 nM
Compound 4: middle estimate off by 4.5-fold (0.66 log units), on the high side; low and high end bracket the measured number.
By their numbers in this assay, from the lowest: compounds 4, 3 and 1 (each within the scatter of the next, the first and the last beyond it); then compound 2.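

Among the compounds shown here, the step of a 2.2-fold lower number from compound 1 to compound 4 (0.33 log units; beyond the scatter) in this assay is the first reading of an exchange at this position, the aromatic carbon that lies meta to a chloro group and para to a large group. It shows that the open-chain diethylamino group is not needed here for a low number: 1H-pyrazol-1-yl, with the same count of heavy atoms but built as a five-membered aromatic ring with two nitrogens, not only is accepted but gives a modestly lower number, beyond the usual scatter. No measured property of these compounds accounts for this step, so the direction of the change is known while its cause is not.

Going by these compounds, with a single exchange to go on, it remains open how a morpholine ring, a dimethylamino group or an imidazole ring would fare at this position, and so whether the step belongs to pyrazolyl in particular or to aromatic rings here in general. Also open, on these data alone, is whether the exchange would keep its direction and size on a core bearing a further chloro group, as the core of compound 3 does.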